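This account rests on a few compounds, and the source may have more. Where it says the series, first, only, none or still open, it means among the compounds named here.

Measured so far in a physicochemical assay for lipophilicity, at pH 7.4; on this read-out lower numbers stand for lower lipophilicity and higher numbers for higher lipophilicity:
compound 1 `CCS(=O)(=O)c1ccc(CN(CC(C)C)S(=O)(=O)c2ccc3c(c2)C(O)CC(C2CCOCC2)O3)nc1`: 1.42
compound 2 `CCc1ccc(N(CC(C)C)S(=O)(=O)c2ccc3c(c2)C(O)CC(C2CCOCC2)O3)cc1`: 4.12
compound 3 `CC(C)CN(c1ccc(C#N)cc1)S(=O)(=O)c1ccc2c(c1)C(O)CC(C1CCOCC1)O2`: 3.07

Of these three, compound 2 stands highest at 4.12, clear of the other two. Compound 4 `CCc1ccc(N(CC(C)C)S(=O)(=O)c2ccc3c(c2)C(N)CC(C2CCOCC2)O3)cc1` keeps all of compound 2 except one group: amino in place of hydroxy on a saturated ring carbon. In short, this is amino in place of hydroxy on a saturated ring carbon.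

Within the data shown here, no measured step touches that ring carbon. Two steps replace a group on a sulfonamide nitrogen: a number 2.70 log units higher from compound 1 to compound 2 (beyond the scatter) and a number 1.65 log units higher from compound 1 to compound 3 (beyond the scatter). The third puts cyano in place of ethyl on an aromatic carbon: a number 1.05 log units lower from compound 2 to compound 3 (beyond the scatter). All three are large, so a single swap can move this read-out a long way, but none of them shows the direction for this change. A sizeable fall is still expected, as a judgement without a measured precedent, and the estimated step is a number 1.22 log units lower from compound 2 to compound 4 (beyond the scatter). The estimate for compound 4 is 2.9, with an expected range from 2.2 to 3.7.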

Compound 4, distribution coefficient: 3.08
The estimate for compound 4 lay 0.18 log units below the measured number; low and high end bracket the measured number.
By their numbers in this assay, from the lowest: compound 1; then compounds 3 and 4 (each within the scatter of the next); then compound 2.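

In this assay, among these compounds, amino in place of hydroxy on this saturated ring carbon gives a number 1.04 log units lower from compound 2 to compound 4 (beyond the scatter), so this ring carbon, which no earlier step touched, can also move the read-out a long way. The swap exchanges one heavy atom for another and leaves the counts of hydrogen-bond donors and acceptors unchanged, with no net charge on either group, so those counts alone do not foretell a step of this size. Nothing measured here accounts for the step.

The compounds shown leave open how far a methoxy group, a fluorine atom or a carboxylic acid on this ring carbon would move the number. They also leave open whether the same swap would give a step of similar size in compound 1 or compound 3, which carry other groups elsewhere on the shared core.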